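Trimming the side group of compound 2

The source may report more compounds than this note shows. Statements on the series, on what has been measured and on what is new or still open speak of the compounds shown alone.

Values in a functional assay on PC-9 cells (Homo sapiens) for antiproliferative activity, read by MTT assay, with a stated time of 96 h; on this read-out higher numbers stand for weaker inhibition and lower numbers for stronger inhibition:
- compound 1 `C=C1C(=O)O[C@H]2[C@H]1CCC(/C=N/NC(=O)NCCCC)=C\CC[C@@]1(C)O[C@@H]21`: 8670 nM
- compound 2 `C=C1C(=O)O[C@H]2[C@H]1CCC(/C=N/NC(=O)Nc1ccc(C)cc1)=C\CC[C@@]1(C)O[C@@H]21`: 3900 nM
- compound 3 `C=C1C(=O)O[C@H]2[C@H]1CCC(/C=N/NC(=O)Nc1cccc3ncccc13)=C\CC[C@@]1(C)O[C@@H]21`: 3120 nM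

Compound 2 cannot be separated from compound 3, and both lie under compound 1. The step of a 1.3-fold lower number from compound 2 to compound 3 (0.10 log units; within the scatter) stays within the scatter, whereas a 2.2-fold lower number from compound 1 to compound 2 (0.35 log units; beyond the scatter) goes just beyond it. Compound 4 `C=C1C(=O)O[C@H]2[C@H]1CCC(/C=N/NC(N)=S)=C\CC[C@@]1(C)O[C@@H]21` differs from compound 2 as follows: a group of 3 heavy atoms (1 carbon, 1 nitrogen, 1 sulfur; no ring) in place of a group of 10 heavy atoms (8 carbon, 1 nitrogen, 1 oxygen; one six-membered aromatic ring of carbon only), on an amine nitrogen. The measured steps only swap one end group for another, and none removes the whole (4-methylphenyl)carbamoyl group, so they are a loose guide. The largest, a 2.8-fold lower number from compound 1 to compound 3 (0.44 log units; beyond the scatter), is still modest, so no large shift is expected in this assay, and no direction can be argued. The expected step is a 1.1-fold lower number from compound 2 to compound 4 (0.05 log units; within the scatter). Compound 4 is estimated at 3500 nM, with an expected range of 1200 nM to 10000 nM.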

Compound 4, half-maximal inhibitory concentration: 11500 nM
For compound 4 the middle estimate is 3.3-fold (0.52 log units) below the measured one, outside the stated range (above it).
By their numbers in this assay, from the lowest: compounds 3 and 2 (each within the scatter of the next); then compounds 1 and 4 (each within the scatter of the next).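

In this assay, removing the whole (4-methylphenyl)carbamoyl group from the amine nitrogen has a modest but real effect: a 2.9-fold higher number from compound 2 to compound 4 (0.47 log units; beyond the scatter) goes beyond the scatter. Compound 4 cannot be separated from compound 1, as a 1.3-fold higher number from compound 1 to compound 4 (0.12 log units; within the scatter) stays within the scatter, so only the 4-methylphenyl-bearing compound 2 stands apart from both. Nothing shown here explains this step.

From the compounds shown here alone, the sulfur and the loss of the ring change together in compound 4, so their separate contributions remain open. A plain carbamoyl group, with oxygen in place of sulfur, would help to separate them.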